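The source may hold more compounds than are shown below. What is called first, only, known or untested is meant among the compounds shown, and "the series" means these compounds.

- Compound 1 `CCCCOc1ccc(NS(=O)(=O)c2ccc(N3CCNC3=O)cc2)cc1` gives 870 nM in a functional assay on MCF7 cells (Homo sapiens) for antiproliferative activity, read by sulforhodamine B assay, with a stated time of 48 h; on this read-out higher numbers stand for weaker inhibition and lower numbers for stronger inhibition
- Compound 2 `O=C1NCCN1c1ccc(S(=O)(=O)Nc2ccc(Br)cc2)cc1` gives 240 nM in this assay

Compound 2, at 240 nM, holds the lower of the two numbers, so it is the stronger inhibitor of this pair. Compound 3 `CC(C)Cc1ccc(NS(=O)(=O)c2ccc(N3CCNC3=O)cc2)cc1` differs from compound 2 in one place (isobutyl in place of bromo on an aromatic carbon), with isobutyl in place of bromo on an aromatic carbon. For the measured compounds named here, only one measured step bears on this change, a 3.6-fold lower number from compound 1 to compound 2 (0.56 log units; beyond the scatter), where bromo took the place of butoxy. Read in reverse, that step shows the number rising when bromo gives way to butoxy, a longer group. Isobutyl also brings more atoms than bromo, so a rise in the same direction seems likely, though one pair is thin evidence. The expected step is a 2.1-fold higher number from compound 2 to compound 3 (0.32 log units; beyond the scatter) in this assay. For compound 3 the estimated value is 500 nM, with an expected range from 170 nM to 1500 nM.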

Compound 3, half-maximal inhibitory concentration: > 1000 nM
Compound 3: a limit, no number (the forecaster's own chance of this, stated with the estimate: 2%); middle value at least 2.0-fold (0.30 log units) away from the limit.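

The reading for compound 3 is a limit of the assay and not a number: the limit of > 1000 nM in this assay, at which 1 of the 3 values shown sits. Even so, replacing bromo with isobutyl on this aromatic carbon gives an at least 4.1-fold higher number from compound 2 to compound 3 (0.61 log units; beyond the scatter) and shows that this position tells the two groups apart, with bromo the better of them. Comparing isobutyl with butoxy gives an at least 1.1-fold higher number from compound 1 to compound 3 (0.06 log units; that floor lies within the scatter) and cannot put those two groups in order, so all that can be said is that each gives a higher number than bromo.

On these data alone, how far compound 3 really lies from compound 2 stays unknown behind its limit. Also open, as far as these compounds go, is whether a chlorine or fluorine atom would match bromo here, and how an amine or a carboxylic acid would read at this position.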